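Aryl replacement on the piperazine nitrogen: compound 4 projected

The source may hold more compounds than are shown below. What is called first, only, known or untested is meant among the compounds shown, and "the series" means these compounds.

Of the compounds shown here, three have been measured in a functional assay for antagonist activity at Alpha-1A adrenergic receptor (Oryctolagus cuniculus); on this read-out higher numbers stand for weaker binding and lower numbers for tighter binding. Compound 1 `CN(C)C(=O)c1cccnc1NCCCN1CCN(c2ccccc2C#N)CC1` gives 2 nM and compound 2 `Cc1ccccc1N1CCN(CCCNc2ncccc2C(=O)N(C)C)CC1` gives 2 nM; the step of no change at the digits printed from compound 1 to compound 2 (within the scatter) is within the scatter. Compound 3 `Cc1cnccc1N1CCN(CCCNc2ncccc2C(=O)N(C)C)CC1` gives 200 nM, the highest of the three numbers, with a 100-fold higher number from compound 1 to compound 3 (2.00 log units; beyond the scatter) and a 100-fold higher number from compound 2 to compound 3 (2.00 log units; beyond the scatter) both large.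

Compound 4 `COc1cc(O)ccc1N1CCN(CCCNc2ncccc2C(=O)N(C)C)CC1` is not yet measured. It differs from compound 3 in one place: 4-hydroxy-2-methoxyphenyl in place of 3-methylpyridin-4-yl on an amine nitrogen in a ring. The two steps that bear on it are the ones into compound 3: a 100-fold higher number from compound 1 to compound 3 (2.00 log units; beyond the scatter) and a 100-fold higher number from compound 2 to compound 3 (2.00 log units; beyond the scatter), where a six-membered aromatic ring of carbon only gave way to one with a hetero atom. Among the measured compounds shown here, compound 4 returns to a ring of carbon only, now as 4-hydroxy-2-methoxyphenyl, so a large drop in this assay is expected, though the new substituents have no measured precedent here. The estimated step is a 33-fold lower number from compound 3 to compound 4 (1.52 log units; beyond the scatter). Compound 4 is expected at 6 nM, within 1.5 nM to 40 nM.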

Compound 4, dissociation constant: 12.6 nM
For compound 4 the middle estimate is 2.1-fold (0.32 log units) below the measured one, within the range that was stated.
By their numbers in this assay, from the lowest: compounds 1 and 2 (each within the scatter of the next); then compound 4; then compound 3.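

In this assay a six-membered aromatic ring of carbon only on this amine nitrogen, now as 4-hydroxy-2-methoxyphenyl, brings a 16-fold lower number from compound 3 to compound 4 (1.20 log units; beyond the scatter) and so regains much of the ground lost with 3-methylpyridin-4-yl. The recovery is partial, with a 6.3-fold higher number from compound 2 to compound 4 (0.80 log units; beyond the scatter) and a 6.3-fold higher number from compound 1 to compound 4 (0.80 log units; beyond the scatter) both beyond the scatter, so this position accepts a ring carrying hydroxy and methoxy groups, but that ring does not match 2-methylphenyl or 2-cyanophenyl. No measurement shown here explains either the recovery or the remaining gap.

From the compounds shown here alone, compound 4 carries both groups at once, so the share of each in these steps stays open, and a 2-methoxyphenyl or a 4-hydroxyphenyl group on the same nitrogen would separate them. Also open, going by these compounds, is whether a 2-methoxypyridin-4-yl group would behave like 3-methylpyridin-4-yl or like the carbon-only rings.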